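This account rests on a few compounds, and the source may have more. Where it says the series, first, only, none or still open, it means among the compounds named here.

Measured compounds:
Compound 1, `N#C/C(=C\c1ccc(O)c(O)c1)C(=O)OC1CCCCC1`, in a functional assay on the whole organism (strain CD1) for inhibition, with Mus musculus as the target, with stated times of 15 min and 20 min, at a dose of 10 mg/kg by the subcutaneous route (on this read-out lower numbers stand for less inhibition and higher numbers for more inhibition at the one dose given (going by the name of the read-out)), gives 55.3%.
Compound 2, `CCOC(=O)/C(C#N)=C/c1ccoc1`, in this assay gives 55.9%.

Compound 2 is the starting point here; the number for compound 1 lies within the scatter of it, so the two measured compounds cannot be told apart. Compound 3, `CC(C)CCOC(=O)/C(C#N)=C/c1ccoc1`, has not yet been measured. It differs from compound 2 in one place: isopropyl in place of hydrogen on a saturated chain carbon, two bonds along the chain from an oxygen next to a carbonyl group. Going by the values given here, no step between measured compounds bears on this change, and compound 1 and compound 2, which differ in several places, give numbers within the scatter of each other. The step of a number 0.9 percentage points lower from compound 2 to compound 3 (within the scatter) is expected to stay within the scatter. Compound 3 is therefore estimated at 55%, with a range from 35% to 72%.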

Compound 3, a percentage reported as inhibition, in the whole organism at one dose (the size of the read-out at that dose, not a potency): 82.2%
For compound 3 the middle estimate is 27.2 percentage points below the measured one; the measured number lies above the stated range.
By their numbers in this assay, from the lowest: compounds 1 and 2 (each within the scatter of the next); then compound 3.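

In this assay, isopropyl in place of hydrogen on a saturated chain carbon, two bonds along the chain from an oxygen next to a carbonyl group, gives a number 26.3 percentage points higher from compound 2 to compound 3 (beyond the scatter). This single change shows that the read-out responds to what this position carries, which the earlier pair, differing in several places, could not show. No measurement available here accounts for the rise.

The compounds shown leave open whether the branching matters, as an unbranched pentyl chain would test. They also leave open whether an amine at the end of this chain would keep the higher number.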